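Swapping a Pyridyl Ring for an Oxolane on the Core

This account rests on a few compounds, and the source may have more. Where it says the series, first, only, none or still open, it means among the compounds named here.

Among the measured compounds shown here, compound 2 `Cc1cc2nc(-c3ccncc3)n(-c3ccc4c(N)nc(N)nc4c3)c2cc1C` gives 437 nM in an assay on isolated protein for inhibition of Dihydrofolate reductase (Homo sapiens), read by spectrophotometry, using NADPH, with a stated time of 10 min (a lower number here means a stronger inhibitor, a higher number a weaker inhibitor), the lowest of the two numbers measured so far; compound 1 `Cc1cc2ncn(-c3ccc4c(N)nc(N)nc4c3)c2cc1C` gives 1610 nM. For the measured compounds named here, the only measured step, a 3.7-fold lower number from compound 1 to compound 2 (0.57 log units; beyond the scatter), shows that a group at this spot can matter. Compound 3 `Cc1cc2nc(C3CCOC3)n(-c3ccc4c(N)nc(N)nc4c3)c2cc1C` carries the change (oxolan-3-yl in place of pyridin-4-yl on an aromatic carbon). Going by the values given here, no measured step covers this exact exchange, and the modest gain seen in going from compound 1 to compound 2 may not carry over to a non-aromatic ring. A somewhat weaker result than compound 2 is therefore expected, estimated as a 1.7-fold higher number from compound 2 to compound 3 (0.23 log units; within the scatter). Compound 3 is expected at 750 nM, within 300 nM to 2000 nM.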

Compound 3, inhibition constant: > 5000 nM
Compound 3 gave a limit, no number; the forecaster's own chance of this, stated with the estimate: 3%; middle value at least 6.6-fold (0.82 log units) away from the limit.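

Compound 3 gave no number, only a limit: the limit of > 5000 nM in this assay, at which 1 of the 3 values shown sits. Exchanging the pyridin-4-yl ring for oxolan-3-yl gives an at least 11-fold higher number from compound 2 to compound 3 (1.05 log units; beyond the scatter), so the gain at this position does not carry over to every ring. Oxolan-3-yl in place of hydrogen gives an at least 3.1-fold higher number from compound 1 to compound 3 (0.49 log units; beyond the scatter), the opposite direction to pyridin-4-yl, so filling this position does not by itself lower the number.

Still open, as far as these compounds go, is whether phenyl, an aromatic ring without the nitrogen, would keep the gain of compound 2. Equally open, from the compounds shown here alone, is how a non-aromatic ring carrying an amine, such as piperidin-4-yl, would compare.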